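Replacing the Amide Aryl Group with a Butyl Chain

The source may report more compounds than this note shows. Statements on the series, on what has been measured and on what is new or still open speak of the compounds shown alone.

Measured compounds:
Compound 1 `O=C(Nc1cc(-c2ccccc2)nc(-c2ccccc2)n1)c1ccccc1` gives 1300 nM in an assay on HEK293 cells for displacement of a labelled ligand from adenosine receptor A3 (Homo sapiens); a lower number here means a stronger inhibitor, a higher number a weaker inhibitor.
Compound 2 `COc1ccc(C(=O)Nc2cc(-c3ccccc3)nc(-c3ccccc3)n2)cc1` gives 1170 nM in this assay.

Compound 1 and compound 2 share the same core and differ only at the amide substituent, where compound 2 carries a methoxy group on the aromatic ring. Compound 2 stands at the lower of the two numbers in this assay, but the gap to compound 1, a 1.1-fold lower number from compound 1 to compound 2 (0.05 log units; within the scatter), lies within the scatter, so the two compounds are not distinguishable on these data.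

Compound 3 `CCCCC(=O)Nc1cc(-c2ccccc2)nc(-c2ccccc2)n1` has not yet been measured. It differs from compound 2 by butyl in place of 4-methoxyphenyl on a carbonyl carbon. Within the data shown here, the single measured step, a 1.1-fold lower number from compound 1 to compound 2 (0.05 log units; within the scatter), concerns only a methoxy group on an aromatic carbon and does not bear on exchanging the whole aryl group for a chain. Among the measured compounds shown here, no measured step therefore informs this change directly, and the expectation rests on the absence of any large effect at the amide position so far. Compound 3 is expected to show a 1.3-fold higher number from compound 2 to compound 3 (0.11 log units; within the scatter) in this assay, with a wide uncertainty. The estimate for compound 3 is 1500 nM, within a range from 400 nM to 6000 nM.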

Compound 3, inhibition constant: 392 nM
Beside the measured number, compound 3's estimate is 3.8-fold (0.58 log units) above it; measured number below the stated range.
By their numbers in this assay, from the lowest: compound 3; then compounds 2 and 1 (each within the scatter of the next).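

At the amide position of the shared core, the group on the carbonyl carbon does matter in this assay: butyl in place of 4-methoxyphenyl gives a 3.0-fold lower number from compound 2 to compound 3 (0.47 log units; beyond the scatter) and butyl in place of phenyl gives a 3.3-fold lower number from compound 1 to compound 3 (0.52 log units; beyond the scatter) whereas the methoxy exchange on the aromatic ring had given only a 1.1-fold lower number from compound 1 to compound 2 (0.05 log units; within the scatter) and so had shown no effect at this position. Both steps beyond the scatter run the same way, so an aromatic ring on this carbonyl carbon is not needed for the lowest number among these three compounds, and compound 3, which carries no ring there, holds that place. Nothing available explains why the chain gives the lower number, and the shift remains an observation without a cause.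

From the compounds shown here alone, whether the number depends on chain length remains open, as a propyl or a hexyl chain could show, and a branched tert-butyl group would test whether the shape of the chain counts as well. A cyclohexyl group would separate the loss of the aromatic ring from the loss of any ring, which butyl alone cannot do.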